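This account rests on a few compounds, and the source may have more. Where it says the series, first, only, none or still open, it means among the compounds named here.

Measured so far in a functional assay on MCF7 cells (Homo sapiens) for antiproliferative activity, read by CCK-8 assay, with a stated time of 72 h; a lower number here means a stronger inhibitor, a higher number a weaker inhibitor:

Compound 1, `Cc1ccc(C(=O)Nc2cccc(-c3oc4cc(-c5ccc(F)cc5)ccc4c(=O)c3O)c2)cc1`: 2400 nM
Compound 2, `Cc1cc(C)cc(C(=O)Nc2cccc(-c3oc4cc(-c5ccc(F)cc5)ccc4c(=O)c3O)c2)c1`: 20400 nM

Compound 1 holds the lowest of these two numbers; the nearest is compound 2, reached by an 8.5-fold higher number from compound 1 to compound 2 (0.93 log units; beyond the scatter). Within the data shown here, that single step is the only measured comparison within this small set, and it shows that changing the substitution pattern on the aromatic ring attached to the carbonyl carbon can weaken inhibition by a modest but real amount.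

Compound 3 is `O=C(Nc1cccc(-c2oc3cc(-c4ccc(F)cc4)ccc3c(=O)c2O)c1)c1cc(F)cc(F)c1` and has not yet been measured. It differs from compound 1 in one place: 3,5-difluorophenyl in place of 4-methylphenyl on a carbonyl carbon. Among the measured compounds shown here, of the measured steps, only the one from compound 1 to compound 2 bears on this change, since it too replaces the 4-methylphenyl with a ring carrying two groups at the 3 and 5 positions, there methyl groups rather than fluorines. With no measurement of a fluorinated ring available, the estimate rests on that one step alone. A weakening of inhibition is therefore expected, though a smaller one than with compound 2, since fluorine and methyl are different groups and nothing shows they act alike.

The expected step for compound 3 is a 2.5-fold higher number from compound 1 to compound 3 (0.40 log units; beyond the scatter), giving an estimate in this assay of 6000 nM, with a range from 2000 nM to 20000 nM.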

Compound 3, half-maximal inhibitory concentration: 2490 nM
For compound 3 the middle estimate is 2.4-fold (0.38 log units) above the measured one, and the stated range covers the measured number.
By their numbers in this assay, from the lowest: compounds 1 and 3 (each within the scatter of the next); then compound 2.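

Swapping the 4-methylphenyl group on this carbonyl carbon for 3,5-difluorophenyl gives a 1.0-fold higher number from compound 1 to compound 3 (0.02 log units; within the scatter) in this assay and so leaves the reading unchanged within the scatter, which shows that this position accepts more than one kind of substituted phenyl ring. Having groups at the 3 and 5 positions is therefore not enough on its own to weaken inhibition, since the two compounds with such a ring part clearly: 3,5-difluorophenyl in place of 3,5-dimethylphenyl gives an 8.2-fold lower number from compound 2 to compound 3 (0.91 log units; beyond the scatter) and so the identity of the two groups matters here, not only where they sit. No evidence at hand accounts for this difference between the fluorine and methyl groups.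

The compounds shown leave open whether the weaker reading of compound 2 belongs to the methyl groups in particular, a question that a 3,5-dichlorophenyl or 3,5-dimethoxyphenyl ring at the same place could help to settle. They also leave open how a ring carrying an amine or a carboxylic acid, or a longer chain in place of the ring, would read in this assay.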